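The source may report more compounds than this note shows. Statements on the series, on what has been measured and on what is new or still open speak of the compounds shown alone.

Series notes. Among the compounds with values here, compound 1 `O=C(Nc1cccc(F)c1)N[C@H]1CC[C@H](Oc2ccc(F)cc2)CC1` is the only compound with a number in a functional assay on CRL2813 cells (Homo sapiens) for cytotoxicity, read by sulforhodamine B assay, with a stated time of 5 days; a higher number here means a weaker inhibitor, a lower number a stronger inhibitor: compound 1 gives 8300 nM. The other value shown is a limit of the assay: compound 2 `COc1ccccc1NC(=O)N[C@H]1CC[C@H](Oc2ccc(F)cc2)CC1` gives > 20000 nM in this assay, a limit rather than a number. Within the data shown here, the step of an at least 2.4-fold higher number from compound 1 to compound 2 (0.38 log units; beyond the scatter) is the only measured step on the aryl attached to the urea nitrogen, and it runs toward weaker inhibition, ending at the limit of > 20000 nM in this assay, at which 1 of the 2 values shown sits.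

Compound 3 `O=C(Nc1cccc(C(=O)O)c1)N[C@H]1CC[C@H](Oc2ccc(F)cc2)CC1` differs from compound 1 by carboxy in place of fluoro on an aromatic carbon. Among the measured compounds shown here, the one measured step bearing on it is the change on the same ring, an at least 2.4-fold higher number from compound 1 to compound 2 (0.38 log units; beyond the scatter), which ended at the limit of the assay. A comparable outcome is expected here: a higher number in this assay, plausibly reaching the limit again, so the step of a 2.4-fold higher number from compound 1 to compound 3 (0.38 log units; beyond the scatter) is the expected size and direction. Compound 3 is estimated at 20000 nM, with a range from 8000 nM to 60000 nM.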

Compound 3, half-maximal inhibitory concentration: > 20000 nM
Compound 3 gave a limit, no number; the forecaster's own chance of this, stated with the estimate: 55%; the middle value lies on the limit itself.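

With carboxy in place of fluoro at the same ring position, the change gives an at least 2.4-fold higher number from compound 1 to compound 3 (0.38 log units; beyond the scatter), so reaching the limit in this assay is not confined to the 2-methoxyphenyl of compound 2. Compound 3 gives > 20000 nM, a limit rather than a number, so the step shows direction and a minimum size but not the full size. Compound 1 remains the only compound with a number, the step between compound 2 and compound 3 cannot be read, and the assay ceiling now governs most of the series: the limit of > 20000 nM in this assay, at which 2 of the 3 values shown sit.

The compounds shown leave open whether an amine or a methyl ester at this ring position would give a number in this assay. They also leave open whether any replacement for fluoro here would give a lower number than compound 1.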